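This account rests on a few compounds, and the source may have more. Where it says the series, first, only, none or still open, it means among the compounds named here.

In a functional assay on HepG2 cells (Homo sapiens) for antiproliferative activity, read by MTT assay (a higher number here means a weaker inhibitor, a lower number a stronger inhibitor), three compounds of a shared core, each a thiourea bearing an aryl ring with different substituents, have been measured. Compound 1 `CNC(=O)c1ccc(Oc2cccc(NC(=S)Nc3ccc(C)c(C)c3)c2)nc1` carries methyl groups on that ring. Compound 1 reaches only the limit of > 100000 nM, so no number is known for it; the limit of > 100000 nM in this assay, at which 1 of the 3 values shown sits, marks where it sits. Compound 2 `CNC(=O)c1ccc(Oc2cccc(NC(=S)Nc3ccc(Br)c(C(F)(F)F)c3)c2)nc1` carries a bromine and a trifluoromethyl group, and in this assay compound 2 gives 8530 nM. Compound 3 `CNC(=O)c1ccc(Oc2cccc(NC(=S)Nc3cc(C(F)(F)F)cc(C(F)(F)F)c3)c2)nc1` carries trifluoromethyl groups on that ring, and in this assay compound 3 gives 4550 nM. Among the numbers available, compound 3 has the lowest, but its gap to compound 2 is within the usual scatter, so the two cannot be ordered.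

Compound 4 `CNC(=O)c1ccc(Oc2cccc(NC(=S)Nc3cccc(C(F)(F)F)c3)c2)nc1` has not yet been measured. It differs from compound 3 by hydrogen in place of trifluoromethyl on an aromatic carbon. Within the data shown here, no step between measured compounds mirrors this change, so the expectation rests on what the measured compounds show: compound 1, with only methyl groups, reaches only the limit > 100000 nM, while compounds bearing a trifluoromethyl group give numbers. Removing one trifluoromethyl group from compound 3 is therefore expected to weaken the inhibitor, with a step of a 3.3-fold higher number from compound 3 to compound 4 (0.52 log units; beyond the scatter) in this assay. For compound 4 the estimated value is 15000 nM, within a range from 5000 nM to 60000 nM.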

Compound 4, half-maximal inhibitory concentration: 23300 nM
Compound 4: the middle estimate sits 1.6-fold (0.19 log units) below what was measured, and the stated range covers the measured number.
By their numbers in this assay, from the lowest: compounds 3 and 2 (each within the scatter of the next); then compound 4. At a limit, above all of these: compound 1.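

In this assay, the second trifluoromethyl group of compound 3 turns out to matter: with hydrogen in its place on this aromatic carbon, the result is a clear loss (with a 5.1-fold higher number from compound 3 to compound 4 (0.71 log units; beyond the scatter)). Compound 2 shows the same direction when hydrogen replaces bromo (with a 2.7-fold higher number from compound 2 to compound 4 (0.44 log units; beyond the scatter)), so although compounds 2 and 3 cannot be ordered against each other, both now stand apart from compound 4, and in these two compounds a second group on the ring, either trifluoromethyl or bromo, goes with the lower number. A single trifluoromethyl group still counts for something, as 3-(trifluoromethyl)phenyl in place of 3,4-dimethylphenyl gives a step in the favourable direction (with an at least 4.2-fold lower number from compound 1 to compound 4 (0.63 log units; beyond the scatter)), but that step is only a bound, since compound 1 stands at a limit and not at a number: the limit of > 100000 nM in this assay, at which 1 of the 4 values shown sits.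

On these data alone, what remains open is whether a chlorine, a methoxy group or a nitrile on this aromatic carbon would hold the number of compound 3 or fall back towards that of compound 4. The values shown also cannot tell why the second group matters, as they come from a single read-out in whole cells.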